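The source may hold more compounds than are shown below. What is called first, only, known or untested is meant among the compounds shown, and "the series" means these compounds.

Compound 2 `CC1=CC[C@@H]([C@@](C)(O)CCCC(C)(C)NC(=S)N/N=C\c2ccccc2)CC1` is the point of departure. In a functional assay on UACC-62 cells (Homo sapiens) for cytotoxicity, read by sulforhodamine B assay (on this read-out lower numbers stand for stronger inhibition of growth and higher numbers for weaker inhibition of growth), compound 2 gives 12700 nM. The simpler compound 1 `CC1=CC[C@@H]([C@@](C)(O)CCCC(C)(C)NC=S)CC1`, which carries only a bare thiocarbonyl arm, gives 9960 nM in this assay; the step is a 1.3-fold higher number from compound 1 to compound 2 (0.11 log units; within the scatter). Compound 3 `CC1=CC[C@@H]([C@@](C)(O)CCCC(C)(C)NC(=S)N/N=C\c2ccccc2[N+](=O)[O-])CC1`, which carries a nitro group on its aromatic ring, gives 6050 nM in this assay; the step is a 2.1-fold lower number from compound 2 to compound 3 (0.32 log units; beyond the scatter). Compound 2 therefore carries the largest of the three numbers, but compound 1 cannot be told apart from it, and only compound 3 sits clearly beyond it.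

Compound 4 `CC1=CC[C@@H]([C@@](C)(O)CCCC(C)(C)NC(=S)N/N=C(/C)c2ccccc2)CC1` has not yet been measured. It differs from compound 2 by a group of 9 heavy atoms (8 carbon, 1 nitrogen; one six-membered aromatic ring of carbon only) in place of a group of 8 heavy atoms (7 carbon, 1 nitrogen; one six-membered aromatic ring of carbon only), on an amide-type nitrogen. For the measured compounds named here, no measured step makes this exact swap. The nearest guide is the step from compound 1 to compound 2, where building the whole arm barely moved the number, and the step from compound 2 to compound 3, where a change on the aromatic ring gave only a modest shift. The closely related arm of compound 4 is therefore expected to produce no step beyond the scatter, with an estimated step of a 1.2-fold lower number from compound 2 to compound 4 (0.06 log units; within the scatter). Compound 4 is expected to give about 11000 nM, in a range from 5000 nM to 25000 nM.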

Compound 4, concentration for 50% growth inhibition: 22400 nM
For compound 4 the middle estimate is 2.0-fold (0.31 log units) below the measured one, within the range that was stated.
By their numbers in this assay, from the lowest: compounds 3, 1, 2 and 4 (each within the scatter of the next, the first and the last beyond it).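

In this assay, a 1.8-fold higher number from compound 2 to compound 4 (0.25 log units; within the scatter), so compound 2 and compound 4 cannot be told apart, even though the group on the amide-type nitrogen has grown by one carbon. This is the first change among these compounds that keeps the arm in place and leaves the aromatic ring unsubstituted: the group that enters has the same six-membered aromatic ring, the same double bond outside the ring, and the same counts of hydrogen-bond donors and acceptors as the group that leaves. At this position, then, a difference as small as this one carbon leaves no readable mark on growth inhibition, although a single pair of compounds says this for this one swap only. Going by these compounds, how the number would respond to a longer chain in place of that added carbon, or to an amine on the aromatic ring of compound 4, stays open. Nothing available bears on why compound 2 and compound 4 read alike.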